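A few compounds are considered here, and "the series" means these few. Any claim that something is new, unique, unknown or untested is made for them only; others in the source may bear on it.

Compound 2 `CCOC(=O)c1cnc(N2CCN(Cc3cc(F)cc(F)c3)CC2)nc1Oc1c(C)cc(-c2ccc(C#N)cc2)cc1C` in an ADME assay on MT4 cells (Homo sapiens) for cytotoxicity, read by MTT assay, with a stated time of 4 days (on this read-out higher numbers stand for lower toxicity in this test and lower numbers for higher toxicity in this test), gives > 125000 nM, which is a limit of the assay rather than a number. Compound 1 `CCOC(=O)c1cnc(N2CCN(Cc3ccccc3F)CC2)nc1Oc1c(C)cc(-c2ccc(C#N)cc2)cc1C` in this assay gives > 125000 nM, likewise a limit. The step that the two limits leave unreadable from compound 1 to compound 2 cannot be read, and the limit of > 125000 nM in this assay, at which 2 of the 2 values shown sit, is all the two values show. Compound 3 `CCOC(=O)c1cnc(N2CCN(Cc3ccc(S(N)(=O)=O)cc3)CC2)nc1Oc1c(C)cc(-c2ccc(C#N)cc2)cc1C` differs from compound 2 by 4-sulfamoylphenyl in place of 3,5-difluorophenyl on a saturated chain carbon bound to an amine nitrogen in a ring. For the measured compounds named here, no measured step bears on this change. Because both values sit at the limit of > 125000 nM in this assay, at which 2 of the 2 values shown sit, compound 3 is expected to return the same limit, with a number no higher from compound 2 to compound 3 (the limit leaves the size open) expected as no step beyond the scatter. For compound 3 the estimate is 125000 nM, between 100000 nM and 200000 nM.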

Compound 3, half-maximal cytotoxic concentration: >= 7930 nM
Compound 3: only a limit was reported; the forecaster's own chance of this, stated with the estimate: 85%; the middle value is on the limit's open side.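

In this assay compound 3 gives >= 7930 nM, a limit and not a number. The steps from compound 1 and compound 2 to compound 3 therefore cannot be read. The compounds shown leave open where the actual values of all three lie and whether changing the benzyl group alters them.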